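This account rests on a few compounds, and the source may have more. Where it says the series, first, only, none or still open, it means among the compounds named here.

In an assay on cell membranes for displacement of a labelled ligand from corticotropin-releasing factor receptor 1 (Rattus norvegicus) (on this read-out higher numbers stand for weaker inhibition and lower numbers for stronger inhibition), three compounds built on one shared core have been measured. Compound 1 `CCCCN(CC)c1nc(C)nc2c(-c3ccc(OC)cc3C)c(C)nn12` gives 2.3 nM, compound 2 `COc1cc(C)c(-c2c(C)nn3c(NC4CCC4)nc(C)nc23)c(OC)c1` gives 17.4 nM, and compound 3 `CCN(CCC#N)c1nc(C)nc2c(-c3c(C)cc(OC)cc3OC)c(C)nn12` gives 2.48 nM. Among the measured compounds shown here, compound 3 thus stands second highest of the three: its number and that of compound 1 lie within the scatter of each other, while the only change beyond the scatter is a 7.0-fold lower number from compound 2 to compound 3 (0.85 log units; beyond the scatter), a modest step.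

Compound 4 `CCC1CCCCN1c1nc(C)nc2c(-c3c(C)cc(OC)cc3OC)c(C)nn12` has not yet been measured. It differs from compound 3 in one place: 2-ethylpiperidin-1-yl in place of (2-cyanoethyl)(ethyl)amino on an aromatic carbon. The entering group, like the leaving one, is joined to the aromatic carbon through its nitrogen and has no hydrogen-bond donor, whereas the cyclobutylamino group of compound 2 had one. For the measured compounds named here, the step from compound 2 to compound 3 is the only measured change on this aromatic carbon, and it concerns the loss of that donor rather than the shape of a donor-free group. Compound 1 carries yet another donor-free group and gives 2.3 nM, within the scatter of compound 3, so two different donor-free groups here give similar numbers.

Compound 4 is therefore expected to give about 3 nM, within a range of 1 nM to 10 nM. This corresponds to an expected step of a 1.2-fold higher number from compound 3 to compound 4 (0.08 log units; within the scatter), none beyond the scatter.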

Compound 4, half-maximal inhibitory concentration: 3.26 nM
Compound 4: the middle estimate sits 1.1-fold (0.04 log units) below what was measured; the measured number falls inside the stated range.
By their numbers in this assay, from the lowest: compounds 1, 3 and 4 (each within the scatter of the next); then compound 2.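

On the aromatic carbon between two ring nitrogen atoms, the open chain of compound 3 can be replaced by a six-membered non-aromatic ring carrying an ethyl group, and this assay shows only a 1.3-fold higher number from compound 3 to compound 4 (0.12 log units; within the scatter) for that change. The nitrile of the leaving chain is therefore not needed to keep the number in this range, at least when this ring takes its place. The second new step is a 5.3-fold lower number from compound 2 to compound 4 (0.73 log units; beyond the scatter) and, together with the earlier step from compound 2 to compound 3, it sets the cyclobutylamino group, which has a hydrogen-bond donor, apart from two different donor-free groups, although no measurement shown explains this difference.

The compounds shown leave open how plain piperidin-1-yl, without the ethyl group, or morpholin-4-yl, with an oxygen atom in the ring, would read on this carbon. They also cannot separate the donor from the shape of the group, a question that a pair such as cyclohexylamino and diethylamino could help to address.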